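The source may report more compounds than this note shows. Statements on the series, on what has been measured and on what is new or still open speak of the compounds shown alone.

In a functional assay on HEK293 cells for agonist activity at G-protein coupled receptor 39 (Homo sapiens), read by scintillation proximity assay and inositol phosphate accumulation, with a stated time of 75 min, in the presence of a further agent that is not named here (on this read-out higher numbers stand for an effect only at larger amounts of compound and lower numbers for an effect already at smaller amounts), compound 1 `Cc1nn(-c2ncnc3nc[nH]c23)c2c1C(OCc1ccc(C(C)C)cc1)CC(=O)N2` gives 5 nM. Within the data shown here, compound 2 `Cc1cc(C)n(CCOC2CC(=O)Nc3c2c(C)nn3-c2ncnc3nc[nH]c23)n1` gives 16 nM, the highest of the two numbers, and the single measured step, a 3.2-fold higher number from compound 1 to compound 2 (0.51 log units; beyond the scatter), sets it apart from compound 1. Compound 3 `CCCCCCCCOC1CC(=O)Nc2c1c(C)nn2-c1ncnc2nc[nH]c12` differs from compound 2 in one place: hexyl in place of 3,5-dimethyl-1H-pyrazol-1-yl on a saturated chain carbon, two bonds along the chain from an oxygen on a saturated carbon. Among the measured compounds shown here, no measured step covers an exchange of this kind, so that modest step between compound 1 and compound 2 offers only a loose guide. The expected step is a 1.3-fold lower number from compound 2 to compound 3 (0.12 log units; within the scatter). Compound 3 is therefore estimated at 12 nM, with a range from 3 nM to 50 nM.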

Compound 3, half-maximal effective concentration: 8 nM
The estimate for compound 3 lay 1.5-fold (0.18 log units) above the measured number, within the range that was stated.
By their numbers in this assay, from the lowest: compounds 1, 3 and 2 (each within the scatter of the next, the first and the last beyond it).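

In compound 1 and compound 2 the side chain carries a ring, whereas in compound 3 it is a plain chain with no ring: hexyl in place of 3,5-dimethyl-1H-pyrazol-1-yl gives a 2.0-fold lower number from compound 2 to compound 3 (0.30 log units; within the scatter), and heptyl in place of 4-isopropylphenyl gives a 1.6-fold higher number from compound 1 to compound 3 (0.20 log units; within the scatter). A ring at this place is therefore not required for a low number in this assay, and neither are the hydrogen-bond acceptors of the pyrazole. No available evidence accounts for this tolerance. On these data alone, whether a shorter chain such as butyl, or an amine or a carboxylic acid at the chain end, would keep the number in this range remains open.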